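Ethoxycarbonyl to Hydroxymethyl Exchange Across Two Related Cores

The source may hold more compounds than are shown below. What is called first, only, known or untested is meant among the compounds shown, and "the series" means these compounds.

Compound 1 `C=CC(=O)Nc1ccc(Cn2nc(-c3ccc(Oc4ccccc4)cc3)cc2C(=O)OCC)cc1` is the reference point of this small set. In a functional assay on Rec1 cells (Homo sapiens) for inhibition, read by luminescence and CellTiter-Glo, with a stated time of 72 h (a higher number here means a weaker inhibitor, a lower number a stronger inhibitor), compound 1 gives 2800 nM. Compound 2 `C=CC(=O)Nc1cccc(Cn2nc(-c3ccc(Oc4ccccc4)cc3)cc2C(=O)OCC)c1` is built from the same atoms joined differently; the difference between the two cores is 3-((vinylcarbonyl)amino)phenyl in place of 4-((vinylcarbonyl)amino)phenyl on a saturated chain carbon bound to an aromatic nitrogen. In this assay compound 2 gives 3300 nM, and the step of a 1.2-fold higher number from compound 1 to compound 2 (0.07 log units; within the scatter) lies within the scatter. Compound 3 `C=CC(=O)Nc1ccc(Cn2nc(-c3ccc(Oc4ccccc4)cc3)cc2CO)cc1` carries the change hydroxymethyl in place of ethoxycarbonyl on an aromatic carbon on the core of compound 1. In this assay compound 3 gives 3500 nM, so the step of a 1.3-fold higher number from compound 1 to compound 3 (0.10 log units; within the scatter) is also within the scatter. No compound among these three stands apart from the others; all gaps fall within the scatter.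

Compound 4 `C=CC(=O)Nc1cccc(Cn2nc(-c3ccc(Oc4ccccc4)cc3)cc2CO)c1` has not yet been measured. It arises from compound 2 by hydroxymethyl in place of ethoxycarbonyl on an aromatic carbon, the same change that turns compound 1 into compound 3, now made on the core of compound 2. Compound 4 is expected to show a 1.2-fold higher number from compound 2 to compound 4 (0.09 log units; within the scatter), placed beside the earlier 1.3-fold higher number from compound 1 to compound 3 (0.10 log units; within the scatter), and this expectation rests on that step alone. Compound 4 is therefore estimated at 4100 nM, with a range from 2000 nM to 8500 nM.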

Compound 4, half-maximal inhibitory concentration: 1300 nM
The estimate for compound 4 lay 3.2-fold (0.50 log units) above the measured number; the measured number lies below the stated range.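

In this assay, the exchange of ethoxycarbonyl for hydroxymethyl gives a 2.5-fold lower number from compound 2 to compound 4 (0.40 log units; beyond the scatter), a modest step. The same exchange therefore does not carry over with the same outcome from one core to the other, and its result here depends on the core that bears it: the same change on two cores in this assay, a 1.3-fold higher number (0.10 log units; within the scatter) from compound 1 to compound 3 and a 2.5-fold lower number (0.40 log units; beyond the scatter) from compound 2 to compound 4, 3.2-fold (0.50 log units) apart, beyond the scatter of two such steps This rests on a single pair of compounds for each core, so it shows no general rule for the series, and it does not show why the two cores part ways or how the change would behave on any further core.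

The compounds shown leave open whether the lower number seen on the core of compound 2 belongs to hydroxymethyl itself or would also appear with other groups at this place on the five-membered aromatic ring, such as a carboxylic acid, an amine or a longer chain ending in a hydroxyl. They also leave open whether the result holds in any assay other than this one.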